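Compound 2 to compound 3: losing one hydroxy

A few compounds are considered here, and "the series" means these few. Any claim that something is new, unique, unknown or untested is made for them only; others in the source may bear on it.

In an ADME assay on L929 cells (Mus musculus) for cytotoxicity, read by resazurin assay, with a stated time of 72 h (a higher number here means a weaker inhibitor, a lower number a stronger inhibitor), compound 1 `CCc1ccc(C(=O)/C=C/c2ccc3c(c2)B(O)OC3)cc1` gives > 10 ug/mL, which is a limit and not a number. In this assay, compound 2 `O=C(/C=C/c1ccc2c(c1)B(O)OC2)c1ccc(O)c(O)c1` gives > 10 ug/mL, which is also a limit, so compound 2 has no exact standing in the series. The whole record so far is the limit of > 10 ug/mL in this assay, at which 2 of the 2 values shown sit. Compound 3 `O=C(/C=C/c1ccc2c(c1)B(O)OC2)c1ccc(O)cc1` has hydrogen in place of hydroxy on an aromatic carbon, ortho to a hydroxy group (hydrogen in place of hydroxy on an aromatic carbon). The expected change, a step that the limit leaves unreadable from compound 2 to compound 3, stays within the scatter, with no direction expected. For compound 3 the estimated value is 20 ug/mL, with an expected range of 10 ug/mL to 40 ug/mL.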

Compound 3, half-maximal inhibitory concentration: > 10 ug/mL
Compound 3: a limit, no number; the forecaster's own chance of this, stated with the estimate: 80%; the middle value does not contradict the limit.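

In this assay no step can be read among compound 1, compound 2 and compound 3, since each value is a limit: the limit of > 10 ug/mL in this assay, at which 3 of the 3 values shown sit.

The compounds shown leave open whether hydroxy, hydrogen or ethyl on an aromatic carbon changes the read-out at all.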